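This account rests on a few compounds, and the source may have more. Where it says the series, first, only, none or still open, it means among the compounds named here.

The series rests on a shared amide core. For the measured compounds named here, compound 1 `O=C(CCCCC1CCSS1)Nc1ccc(Br)cn1` is the only member with a numerical result: in a functional assay on KB cells (Homo sapiens) for inhibition, read by MTT assay, with a stated time of 24 h, tested at 1 ug/mL (on this read-out higher numbers stand for more inhibition of growth at the one concentration tested and lower numbers for less inhibition of growth), compound 1 gives 4.33%, a figure close to the bottom of the scale. Compound 2 `O=C(CCCCC(S)CCS)Nc1ccccn1` carries an open chain with thiol groups in place of the ring of compound 1 and has no bromo group; in this assay compound 2 is recorded as "not active" (no number reported), a result reported without a number, so compound 2 cannot be placed at a fixed point and stands simply at the low end of the range.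

Compound 3 `O=C(CCCCC(S)CCS)Nc1ccc(Br)cn1` has not yet been measured. It is reached from compound 2 by a single change: bromo in place of hydrogen on an aromatic carbon. Going by the values given here, the only measured compound that already carries the bromo group, compound 1, sits near the floor of the read-out, and compound 2 is reported as inactive. Among the compounds with values here, with no measured step to draw on, the change in this assay from compound 2 to compound 3 is expected to be small, within the scatter, and without a clear direction. Compound 3 is therefore estimated to give 4%, in the range 0% to 15%.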

Compound 3, percent growth inhibition at one concentration: 2.51%
Compound 3: middle estimate off by 1.5 percentage points, on the high side; measured number inside the range.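

The series now has its first readable step in this assay, and it is a number 1.8 percentage points lower from compound 1 to compound 3 (within the scatter), so on the bromo-bearing core the open chain with its thiol groups and the five-membered ring with two sulfur atoms cannot be told apart at this site, on a saturated chain carbon, four bonds along the chain from a carbonyl carbon. For the compounds shown here, the bromo change itself still gives no step, since compound 2 is recorded as "not active" (no number reported) while compound 3 gives 2.51%, and a result without a number cannot be read against a number. Nothing available bears on why these readings lie where they do.

The compounds shown leave open whether any other group on the aromatic carbon, such as a chloro or a methoxy group in place of the bromo, would lift the reading clear of the bottom of the scale at the one concentration tested. Also open, on these data alone, is whether a longer chain, or a carboxylic acid at the end of the chain in place of the thiol-bearing part, would give a reading that differs from those of the two compounds with numbers.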